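Alkylating the ring amine of compound 3: an estimate

A few compounds are considered here, and "the series" means these few. Any claim that something is new, unique, unknown or untested is made for them only; others in the source may bear on it.

Three compounds share one core and differ only in the halogen on the aromatic carbon. Compound 1 `O=S(=O)(c1cccc(Cl)c1)c1cn(C2CCCNC2)c2ncccc12` gives 30 nM in a functional assay on HeLa cells for agonist activity at 5-hydroxytryptamine receptor 6 (Homo sapiens), read by cAMP accumulation and immunoassay; on this read-out lower numbers stand for an effect already at smaller amounts and higher numbers for an effect only at larger amounts of compound. Compound 2 `O=S(=O)(c1cccc(Br)c1)c1cn(C2CCCNC2)c2ncccc12` gives 72 nM, and compound 3 `O=S(=O)(c1cccc(F)c1)c1cn(C2CCCNC2)c2ncccc12` gives 67 nM. Among these three numbers compound 3 holds the second highest place: its nearest neighbour is compound 2, with a 1.1-fold lower number from compound 2 to compound 3 (0.03 log units; within the scatter), and its furthest is compound 1, with a 2.2-fold higher number from compound 1 to compound 3 (0.35 log units; beyond the scatter). The remaining step, a 2.4-fold higher number from compound 1 to compound 2 (0.38 log units; beyond the scatter), is of the same modest size.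

Compound 4 `CC(C)N1CCCC(n2cc(S(=O)(=O)c3cccc(F)c3)c3cccnc32)C1` is built from compound 3 by the change (isopropyl in place of hydrogen on an amine nitrogen in a ring). Within the data shown here, none of the measured steps touches this position: all three concern only the halogen on the aromatic carbon, and no pair among the measured compounds differs at the ring amine. There is therefore no measured step that bears on the change, and nothing in the shown numbers points to a direction. For compound 4 the expectation is accordingly a number close to that of compound 3, a 1.0-fold higher number from compound 3 to compound 4 (0.02 log units; within the scatter), with a range wide enough to allow a shift either way. The estimated value for compound 4 is 70 nM, expected to fall between 20 nM and 250 nM.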

Compound 4, half-maximal effective concentration: 172 nM
For compound 4 the middle estimate is 2.5-fold (0.39 log units) below the measured one; measured number inside the range.
By their numbers in this assay, from the lowest: compound 1; then compounds 3 and 2 (each within the scatter of the next); then compound 4.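

The ring amine, which none of the halogen steps touched, proves to matter in this assay: isopropyl in place of hydrogen on the amine nitrogen gives a 2.6-fold higher number from compound 3 to compound 4 (0.41 log units; beyond the scatter), a modest step beyond the scatter. The change from piperidin-3-yl to 1-isopropylpiperidin-3-yl therefore moves the number upward, so on this read-out compound 4 needs larger amounts of compound for its effect, yet a number in the nanomolar range remains and the position accepts this group without a loss of the read-out. Nothing available gives a reason for this shift.

With isopropyl as the only group shown on this nitrogen, it remains open whether a methyl, an ethyl or a cyclopropyl there would move the number less, more or in the other direction, and whether an acetyl, which would turn the ring amine into an amide, would still give a readable effect. Also open, on these data alone, is whether isopropyl would shift the number by a similar amount on compound 1 or compound 2, which carry chloro and bromo instead of fluoro.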